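This account rests on a few compounds, and the source may have more. Where it says the series, first, only, none or still open, it means among the compounds named here.

The set comprises three measured compounds that share one core. Compound 1 `COc1cc(/C=C/C(=O)C2=C(/C=C/c3ccc(O)c(OC)c3)NC(=O)NC2c2ccc(N(C)C)cc2)ccc1O` carries a 4-(dimethylamino)phenyl on a saturated ring carbon, and in a functional assay, with a stated time of 20 min, tested at 2 uM (on this read-out lower numbers stand for a weaker effect and higher numbers for a stronger effect at the one concentration tested), compound 1 gives 28.2%. Going by the values given here, compound 2 `COc1cc(/C=C/C(=O)C2=C(/C=C/c3ccc(O)c(OC)c3)NC(=O)NC2c2cccc([N+](=O)[O-])c2)ccc1O` bears a 3-nitrophenyl at that place instead, and in this assay compound 2 gives 10.2%; this is the one single-point step among the measured compounds, a number 18 percentage points lower from compound 1 to compound 2 (beyond the scatter). Compound 3 `COc1cc(/C=C/C(=O)C2=C(/C=C/c3ccc(O)c(OC)c3)NC(=S)NC2c2ccccc2)ccc1O` carries a plain phenyl on the saturated ring carbon, and in this assay compound 3 gives 16.6%. That places compound 3 second highest of the three numbers: its value lies within the scatter of compound 2 and beyond the scatter below compound 1.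

Compound 4 `COc1cc(/C=C/C(=O)C2=C(/C=C/c3ccc(O)c(OC)c3)NC(=S)NC2c2ccccc2Cl)ccc1O` is the next compound. It differs from compound 3 by chloro in place of hydrogen on an aromatic carbon, ortho to a large group. Among the compounds with values here, no measured step concerns a substituent on this aromatic ring; the only step measured, a number 18 percentage points lower from compound 1 to compound 2 (beyond the scatter), exchanges the whole aryl group on the saturated ring carbon and is of modest size, so it does not bear directly on a single chloro added to the phenyl. With nothing to point either way, no step beyond the scatter is expected. The step is therefore expected to be a number 0.4 percentage points higher from compound 3 to compound 4 (within the scatter). Compound 4 is estimated at 17%, with a range from 7% to 28%.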

Compound 4, a percentage reported as activity, at one concentration (the size of the read-out at that concentration, not a potency): 15.5%
Estimate against measurement, compound 4: 1.5 percentage points above; the measured number falls inside the stated range.
By their numbers in this assay, from the lowest: compounds 2, 4 and 3 (each within the scatter of the next); then compound 1.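

Chloro in place of hydrogen on an aromatic carbon, ortho to a large group, is the one change in this set that leaves the rest of the aryl group in place, and in this assay it gives a number 1.1 percentage points lower from compound 3 to compound 4 (within the scatter). This single added atom therefore leaves the read-out within the scatter, whereas the exchange of the whole aryl group on the saturated ring carbon gives a number 18 percentage points lower from compound 1 to compound 2 (beyond the scatter), which lies beyond it, so the phenyl of compound 3 accepts a chloro at this place with no change that this read-out can separate from scatter. No measured information bears on why the step is this small.

The compounds shown leave open whether a methoxy group, an amine or a carboxylic acid at this same place would also stay within the scatter of compound 3, and whether chloro would read the same elsewhere on the phenyl. They also leave open whether the same chloro would behave alike on the core of compound 1, and, with one concentration tested, what the potency of any of these compounds is.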